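Silyl Ether Analogue of a Cyclopentenone: Expected Cytotoxicity

The compounds below may be only part of what the source reports. "The series", "measured", "known", "first", "only" and "open" are said of these compounds alone.

Compound 1 `COC(=O)c1cc(C2=C(c3cc(OC)c(OC)c(OC)c3)C(=O)CC2O[SiH2]C(C)(C)C)ccc1OC`: > 100 ug/mL
Compound 2 `COc1ccc(C2=C(c3cc(OC)c(OC)c(OC)c3)C(=O)CC2O)cc1O`: > 100 ug/mL

In an ADME assay on ECV-304 cells (Homo sapiens) for cytotoxicity, read by MTT assay, with a stated time of 72 h (a lower number here means a stronger inhibitor, a higher number a weaker inhibitor), compound 1 gives > 100 ug/mL, a limit of the assay and not a number. Compound 2 likewise gives > 100 ug/mL, again a limit. Compound 2 therefore stands at the limit of > 100 ug/mL in this assay, at which 2 of the 2 values shown sit, so no numbered value places it. Among the measured compounds shown here, no step between measured compounds is known. Compound 3 `COc1ccc(C2=C(c3cc(OC)c(OC)c(OC)c3)C(=O)CC2O[SiH2]C(C)(C)C)cc1O` differs from compound 2 by a group of 5 heavy atoms (4 carbon, 1 silicon; no ring) in place of a hydrogen atom, on an oxygen on a saturated carbon. In this assay no step beyond the usual scatter is expected from this change, and compound 3 most likely returns a limit too. Compound 3 is estimated at 100 ug/mL, in the range 50 ug/mL to 200 ug/mL, a step of a number no higher from compound 2 to compound 3 (the limit leaves the size open).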

Compound 3, half-maximal inhibitory concentration: 30 ug/mL
Beside the measured number, compound 3's estimate is 3.3-fold (0.52 log units) above it, outside the stated range (below it).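

In this assay, the silyl group on the oxygen on a saturated carbon turns a limit into a number, with an at least 3.3-fold lower number from compound 2 to compound 3 (0.52 log units; beyond the scatter). With that group in place, the aromatic carbon also counts, as hydroxy in place of methoxycarbonyl gives an at least 3.3-fold lower number from compound 1 to compound 3 (0.52 log units; beyond the scatter). The full size of both steps stays unknown because each starts from a limit: the limit of > 100 ug/mL in this assay, at which 2 of the 3 values shown sit.

The compounds shown leave open whether a methyl or acetyl group on that oxygen would also lower the number. They also leave open whether an amine in place of the hydroxy would keep the effect.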